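Swapping a pyridine for a trifluoromethylphenyl on the core

This account rests on a few compounds, and the source may have more. Where it says the series, first, only, none or still open, it means among the compounds named here.

Compound 1 `O=C(NO)c1ccc(NCc2nc(-c3cccnc3)nn2-c2ccccc2)cc1` gives the lowest of the two numbers in hand. In an assay on Sf9 cells for inhibition of protein deacetylase HDAC6 (Homo sapiens), read by fluorescence, with a stated time of 40 min, tested at 100 nM (a lower number here means less inhibition, a higher number more inhibition at the concentration tested (going by the name of the read-out)), compound 1 gives 57.7%. Compound 2 `O=C(NO)c1ccc(NCc2nc(-c3ccccc3)nn2-c2ccc(F)cc2)cc1` gives 67.6% in the same assay; the two values sit within the scatter of each other, so neither can be called stronger. Compound 3 `O=C(NO)c1ccc(NCc2nc(-c3ccc(C(F)(F)F)cc3)nn2-c2ccccc2)cc1` differs from compound 1 by 4-(trifluoromethyl)phenyl in place of pyridin-3-yl on an aromatic carbon. Among the measured compounds shown here, no measured step between two compounds differing in a single place is available to guide this change. The expected step of a number 4.3 percentage points higher from compound 1 to compound 3 (within the scatter) is small, not beyond the scatter, in either direction. Compound 3 is therefore estimated at 62%, with a range from 45% to 80%.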

Compound 3, a percentage reported as inhibition, at one concentration (the size of the read-out at that concentration, not a potency): 41.6%
Compound 3: the middle estimate sits 20.4 percentage points above what was measured; the whole stated range lies above it.
By their numbers in this assay, from the lowest: compound 3; then compounds 1 and 2 (each within the scatter of the next).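

Among the compounds shown here, replacing pyridin-3-yl with 4-(trifluoromethyl)phenyl on this aromatic carbon of the core gives a step in this assay of a number 16.1 percentage points lower from compound 1 to compound 3 (beyond the scatter) and this is the first sign that the group held here can change the read-out. The change removes a ring nitrogen and adds a trifluoromethyl group at once, so this single step cannot separate the two. No measurement at hand explains the step.

Which of the two parts matters stays open. Pyridin-4-yl, or a phenyl ring carrying a carboxylic acid or an amine, on this carbon could help to settle that.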